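Swapping the Amide Aryl Group Back Toward Chlorine

The compounds below may be only part of what the source reports. "The series", "measured", "known", "first", "only" and "open" are said of these compounds alone.

Among the measured compounds shown here, compound 2 `Cn1cnc(S(=O)(=O)N2C[C@@H]3[C@H](C2)[C@@]3(CNC(=O)c2cccc(C(F)(F)F)c2)CC2CC2)c1` gives 64 nM in an assay on isolated protein for inhibition of sodium- and chloride-dependent glycine transporter 1 (Homo sapiens) (a higher number here means a weaker inhibitor, a lower number a stronger inhibitor), the highest of the two numbers so far. Compound 1 `Cn1cnc(S(=O)(=O)N2C[C@@H]3[C@H](C2)[C@@]3(CNC(=O)c2ccccc2Cl)CC2CC2)c1` gives 19 nM in this assay. For the measured compounds named here, the only measured step, a 3.4-fold higher number from compound 1 to compound 2 (0.53 log units; beyond the scatter), shows that exchanging 2-chlorophenyl for 3-(trifluoromethyl)phenyl on the carbonyl carbon weakened inhibition. Compound 3 `Cn1cnc(S(=O)(=O)N2C[C@@H]3[C@H](C2)[C@@]3(CNC(=O)c2ccc(Cl)cc2Cl)CC2CC2)c1` differs from compound 2 by 2,4-dichlorophenyl in place of 3-(trifluoromethyl)phenyl on a carbonyl carbon, which brings a chlorine-bearing phenyl back, as in compound 1. That earlier step is expected to largely reverse, giving a 2.6-fold lower number from compound 2 to compound 3 (0.41 log units; beyond the scatter). The estimate for compound 3 is 25 nM, with a range of 8 nM to 80 nM.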

Compound 3, half-maximal inhibitory concentration: 4 nM
Compound 3: middle estimate off by 6.3-fold (0.80 log units), on the high side; measured number outside the range, below it.
By their numbers in this assay, from the lowest: compound 3; then compound 1; then compound 2.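

On the carbonyl carbon, 2,4-dichlorophenyl gives the strongest inhibitor of the three: chloro in place of hydrogen on an aromatic carbon produces a 4.8-fold lower number from compound 1 to compound 3 (0.68 log units; beyond the scatter), and the exchange for 3-(trifluoromethyl)phenyl produces a 16-fold lower number from compound 2 to compound 3 (1.20 log units; beyond the scatter). A second chlorine on the phenyl ring therefore strengthens inhibition further, so one added atom at this part of the molecule can shift the number beyond the scatter. Nothing available explains this gain. The compounds shown leave open whether a phenyl ring carrying only the newly added chlorine would do as well. They also leave open whether bromine, methoxy or nitrile could replace that chlorine.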